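Ester side-chain variations on a shared naphthoquinone core

The source may hold more compounds than are shown below. What is called first, only, known or untested is meant among the compounds shown, and "the series" means these compounds.

Measured compounds:
compound 1 `CCCC(O)CC(=O)O[C@H](CC=C(C)C)C1=CC(=O)c2c(O)ccc(O)c2C1=O`, 59300 nM
compound 2 `CCCCC(O)CC(=O)O[C@H](CC=C(C)C)C1=CC(=O)c2c(O)ccc(O)c2C1=O`, 72200 nM
compound 3 `COCCO[C@H](CC=C(C)C)C1=CC(=O)c2c(O)ccc(O)c2C1=O`, 62400 nM

In a functional assay on HeLa cells (Homo sapiens) for cytotoxicity, read by MTT assay (on this read-out lower numbers stand for stronger inhibition and higher numbers for weaker inhibition), compound 2 gives 72200 nM. Its steps to the others, a 1.2-fold lower number from compound 2 to compound 3 (0.06 log units; within the scatter) and a 1.2-fold higher number from compound 1 to compound 2 (0.09 log units; within the scatter), both lie within the scatter, so the three compounds sit together. Compound 4 `CC(C)=CC[C@@H](OC(=O)C1CCCOC1)C1=CC(=O)c2c(O)ccc(O)c2C1=O` differs from compound 2 by oxan-3-yl in place of 2-hydroxyhexyl on a carbonyl carbon. Both measured steps, one adding a methyl along the chain and one swapping the whole ester for a 2-methoxyethyl ether, left the numbers unchanged, so a change inside the same side chain is expected to give no step beyond the scatter in this assay: a 1.1-fold lower number from compound 2 to compound 4 (0.03 log units; within the scatter). Compound 4 is therefore estimated at 68000 nM, in the range 34000 nM to 136000 nM.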

Compound 4, half-maximal inhibitory concentration: 60500 nM
Estimate against measurement, compound 4: 1.1-fold (0.05 log units) above, within the range that was stated.
By their numbers in this assay, from the lowest: compounds 1, 4, 3 and 2 (each within the scatter of the next).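

In this assay, oxan-3-yl in place of 2-hydroxyhexyl on a carbonyl carbon gives a 1.2-fold lower number from compound 2 to compound 4 (0.08 log units; within the scatter) and oxan-3-yl in place of 2-hydroxypentyl gives a 1.0-fold higher number from compound 1 to compound 4 (0.01 log units; within the scatter) so this position tolerates a six-membered ring and a group with 0 hydrogen-bond donors without a step beyond the scatter. Going from the 2-methoxyethyl ether to the (oxan-3-yl)carbonyl ester gives a 1.0-fold lower number from compound 3 to compound 4 (0.01 log units; within the scatter) and stays within the scatter too. No measurement at hand explains why the numbers stay together. As far as these compounds go, whether an amine, a carboxylic acid or a much longer chain at this position would move the number beyond the scatter remains open.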